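The compounds below may be only part of what the source reports. "The series", "measured", "known", "first", "only" and "open" are said of these compounds alone.

Measured in a functional assay on LNCaP cells (Homo sapiens) for inhibition, read by CellTiter-Glo, with stated times of 7 days and 48 h; on this read-out higher numbers stand for weaker inhibition and lower numbers for stronger inhibition:
- compound 1 `Cc1cccc(C2NC(=O)c3c(Cl)cccc3N2)c1`, 8800 nM
- compound 2 `Cc1cccc(C2NC(=O)c3c(Cl)cccc3N2)c1C`, 660 nM
- compound 3 `Cc1cccc(C)c1C1NC(=O)c2c(Cl)cccc2N1`, 2000 nM

Compound 1 carries the highest number of the three, at 8800 nM. Compound 4 `Cc1cccc(C2NC(=O)c3c(Br)cccc3N2)c1` differs from it in one place: bromo in place of chloro on an aromatic carbon, with bromo in place of chloro on an aromatic carbon. Among the compounds with values here, the only measured single-place step, a 13-fold lower number from compound 1 to compound 2 (1.12 log units; beyond the scatter), is large, but it is methyl in place of hydrogen on an aromatic carbon. Within the data shown here, all measured compounds keep the chloro, so no measured step bears directly on this swap. In this assay no change beyond the scatter is therefore expected. The expected step is a 1.4-fold lower number from compound 1 to compound 4 (0.13 log units; within the scatter). For compound 4 the estimated value is 6500 nM, with an expected range from 2500 nM to 15000 nM.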

Compound 4, half-maximal inhibitory concentration: 9300 nM
Estimate against measurement, compound 4: 1.4-fold (0.16 log units) below; the measured number falls inside the stated range.
By their numbers in this assay, from the lowest: compound 2; then compound 3; then compounds 1 and 4 (each within the scatter of the next).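

In this assay, within the data shown here, bromo in place of chloro on an aromatic carbon gives a 1.1-fold higher number from compound 1 to compound 4 (0.02 log units; within the scatter) and so offers the first reading at this position, which all three earlier compounds left as chloro. Among these compounds, with the single methyl of compound 1, the two halogens are not told apart at this position. No supporting data offer an account of this result.

From the compounds shown here alone, whether this holds with the added methyl of compound 2 remains open. Also open, going by these compounds, is how an amine, a methoxy group or plain hydrogen at this position would read.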